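The source may report more compounds than this note shows. Statements on the series, on what has been measured and on what is new or still open speak of the compounds shown alone.

Measured so far:
compound 1 `CC(=O)/C(C)=N/OCc1cc(=O)oc2ccc(Br)cc12` — 5.4
compound 2 `CC(=O)/C(C)=N/OCc1cc(=O)oc2cc(Cl)ccc12` — 5.4

Both values come from a physicochemical assay for acid dissociation, using potentiometric titration. In this assay, among the compounds with values here, compound 1 gives 5.4 and stands level with compound 2 at the digits printed, within the usual scatter; no step between the two is computed. Compound 3 `CC(=O)/C(C)=N/OCc1cc(=O)oc2ccc(C)cc12` is not yet measured. It differs from compound 1 by methyl in place of bromo on an aromatic carbon. The step is expected to be small, a number 0.10 log units higher from compound 1 to compound 3 (within the scatter), leaning if anything toward a higher number but not clearly beyond the scatter. Compound 3 is expected to give 5.5, within 5.2 to 5.8.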

Compound 3, acid dissociation constant: 5.7
For compound 3 the middle estimate is 0.20 log units below the measured one; low and high end bracket the measured number.
By their numbers in this assay, from the lowest: compounds 1, 2 and 3 (each within the scatter of the next).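

In this assay, within the data shown here, methyl in place of bromo on an aromatic carbon gives a number 0.30 log units higher from compound 1 to compound 3 (within the scatter), the only comparison here between compounds that differ in one place. At this position, meta to a fused ring and para to a fused ring, the read-out therefore does not separate these two groups, which the earlier pair could not show. No measurement on hand explains the result.

As far as these compounds go, whether an amine, a carboxylic acid or a longer chain at this position would move the value beyond the scatter remains open. So does whether the same exchange elsewhere on the shared core would behave alike.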